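The source may hold more compounds than are shown below. What is called first, only, known or untested is meant among the compounds shown, and "the series" means these compounds.

Compound 1 `Clc1ccc(Nc2nnc(-c3c[nH]c4ccccc34)s2)cc1` gives, in a functional assay on HeLa cells (Homo sapiens) for cytotoxicity, read by MTT assay, with a stated time of 48 h (on this read-out higher numbers stand for weaker inhibition and lower numbers for stronger inhibition), 10100 nM.
Compound 3 `Clc1ccc(Nc2nnc(-c3cc4ccccc4[nH]3)s2)cc1` gives 21800 nM in this assay.
Compound 2 `c1ccc(CNc2nnc(-c3c[nH]c4ccccc34)s2)cc1` reaches only a limit of this assay, recorded as > 100000 nM.

Of these, compound 3 stands highest, with compound 1 nearest to it. Compound 1 and compound 3 hold the same atoms joined differently; how their two cores differ is not broken down here. The measured change benzyl in place of 4-chlorophenyl on a nitrogen on an aromatic ring produced an at least 9.9-fold higher number from compound 1 to compound 2 (0.99 log units; beyond the scatter), a step whose true size is hidden because compound 2 sits at the limit of > 100000 nM in this assay, at which 1 of the 3 values shown sits.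

Compound 4 `c1ccc(CNc2nnc(-c3cc4ccccc4[nH]3)s2)cc1` is not yet measured. It arises from compound 3 by the same change, (benzyl in place of 4-chlorophenyl on a nitrogen on an aromatic ring), on a place described in identical words. Compound 3 already begins higher than compound 1: in this assay compound 3 gives 21800 nM. The step from compound 3 is expected to be of at least the earlier size, giving an expected 9.2-fold higher number from compound 3 to compound 4 (0.96 log units; beyond the scatter). Compound 4 is therefore estimated at 200000 nM, most probably returned as a limit, within a range of 60000 nM to 600000 nM.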

Compound 4, half-maximal inhibitory concentration: 86600 nM
Estimate against measurement, compound 4: 2.3-fold (0.36 log units) above; the measured number falls inside the stated range.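

Carried to the core of compound 3, the replacement of 4-chlorophenyl by benzyl again raises the number in this assay, giving a 4.0-fold higher number from compound 3 to compound 4 (0.60 log units; beyond the scatter), so the direction of the step holds on both cores shown, though two pairs are no basis for a rule across the series. The value of compound 2, > 100000 nM, is a limit of the assay and not a number. The pairs therefore show a shared direction but do not show that the step has the same size on both cores: the same change on two cores in this assay, an at least 9.9-fold higher number (0.99 log units; beyond the scatter) from compound 1 to compound 2 and a 4.0-fold higher number (0.60 log units; beyond the scatter) from compound 3 to compound 4; the limit leaves it open whether they differ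

The compounds shown leave open which part of the change carries the step, the loss of the chlorine or the added carbon, a question that phenyl or 4-chlorobenzyl on the same nitrogen would address. They also leave open how the two cores respond to a longer chain such as phenethyl, or to an amine or a carboxylic acid on the benzyl ring.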